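A few compounds are considered here, and "the series" means these few. Any claim that something is new, unique, unknown or untested is made for them only; others in the source may bear on it.

Working notes on the series. Among the measured compounds shown here, compound 2, `O=C1O[C@@H](Cn2ccnn2)CN1c1ccc(N2CCN(Cc3ccc([N+](=O)[O-])o3)CC2)c(F)c1`, stands highest of the two numbers so far in an ADME assay on the whole organism (plasma, strain Sprague-Dawley) for pharmacokinetics, with Rattus norvegicus as the target, at a dose of 10 mg/kg by the intravenous route (on this read-out higher numbers stand for higher exposure at the dose given and lower numbers for lower exposure), where compound 2 gives 18900 ng.h/mL. Its nearest neighbour is compound 1, `Nc1ccc(CN2CCN(c3ccc(N4C[C@H](Cn5ccnn5)OC4=O)cc3F)CC2)cc1`; in this assay compound 1 gives 7080 ng.h/mL. For the measured compounds named here, the only measured step in the set, a 2.7-fold higher number from compound 1 to compound 2 (0.43 log units; beyond the scatter), moves between two aryl groups on a saturated chain carbon bound to an amine nitrogen in a ring.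

Compound 3, `O=C1O[C@@H](Cn2ccnn2)CN1c1ccc(N2CCN(Cc3cccc([N+](=O)[O-])c3)CC2)c(F)c1`, differs from compound 2 by the same kind of exchange at the same place: 3-nitrophenyl in place of 5-nitrofuran-2-yl on a saturated chain carbon bound to an amine nitrogen in a ring. The step from compound 1 to compound 2 is the only one that bears on it, and it was modest; it does not speak to the furan-to-phenyl change directly, only to the scale of what a swap of the aryl group at this position has done in this assay once. The expectation is therefore a step from compound 2 that may fall either side and should be of modest size at most, a 1.5-fold lower number from compound 2 to compound 3 (0.16 log units; within the scatter). The estimate for compound 3 in this assay is 13000 ng.h/mL, with a range from 5500 ng.h/mL to 30000 ng.h/mL.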

Compound 3, area under the concentration-time curve: 26200 ng.h/mL
The estimate for compound 3 lay 2.0-fold (0.30 log units) below the measured number; the range from low to high includes it.
By their numbers in this assay, from the lowest: compound 1; then compounds 2 and 3 (each within the scatter of the next).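

The exchange of 5-nitrofuran-2-yl for 3-nitrophenyl on a saturated chain carbon bound to an amine nitrogen in a ring gives a 1.4-fold higher number from compound 2 to compound 3 (0.14 log units; within the scatter) in this assay, so a five-membered aromatic ring with a hetero atom and a six-membered aromatic ring of carbon only cannot be told apart here when each carries a nitro group. The 4-aminophenyl group of compound 1 now stands apart from both nitro-bearing aryl groups, and no compound shown goes against this: the second comparison gives a 3.7-fold higher number from compound 1 to compound 3 (0.57 log units; beyond the scatter), which adds a phenyl example to the furan one. No measurement shown bears on the reason for this separation, so the numbers stay a description of exposure only.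

The step from 4-aminophenyl to 3-nitrophenyl changes both the substituent and its place on the ring, so the compounds shown do not separate these two changes. Also open, going by these compounds, is how a plain phenyl, or a phenyl carrying a nitrile or a carboxylic acid in place of the nitro group, would stand in this assay against these three compounds.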